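Changing the aryl group on a sulfonamide nitrogen

This account rests on a few compounds, and the source may have more. Where it says the series, first, only, none or still open, it means among the compounds named here.

Compound 1 `O=S(=O)(Nc1ccc(Cl)cc1Cl)c1ccc(-c2cnc(C3CC3)o2)cc1` gives 481 nM
Compound 2 `Cc1ccc(Cl)c(NS(=O)(=O)c2ccc(-c3cnc(C4CC4)o3)cc2)c1` gives 48.8 nM

Among the compounds with values here, in a functional assay on cells (leukaemia cell line, Homo sapiens) for inhibition, read by sulforhodamine B assay, with a stated time of 48 h (on this read-out lower numbers stand for stronger inhibition of growth and higher numbers for weaker inhibition of growth), compound 2 gives 48.8 nM as the lower of the two numbers so far. Compound 3 `Cc1cc(F)cc(NS(=O)(=O)c2ccc(-c3cnc(C4CC4)o3)cc2)c1` has not yet been measured. It carries 3-fluoro-5-methylphenyl in place of 2-chloro-5-methylphenyl on a sulfonamide nitrogen, and 3-fluoro-5-methylphenyl in place of 2-chloro-5-methylphenyl on a sulfonamide nitrogen sets out the change. Within the data shown here, the only measured step at this place is a 9.9-fold lower number from compound 1 to compound 2 (0.99 log units; beyond the scatter) in this assay and lies beyond the scatter. That single step shows the number can respond strongly here, but it gives no rule for the new group. Since compound 2 sits at the better end with 48.8 nM as its number, a move toward weaker inhibition seems likelier. The expected change is a 2.9-fold higher number from compound 2 to compound 3 (0.46 log units; beyond the scatter) in this assay and carries wide uncertainty. For compound 3 the estimated value is 140 nM (35 nM to 550 nM).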

Compound 3, concentration for 50% growth inhibition: 138 nM
The estimate for compound 3 lay 1.0-fold (0.01 log units) above the measured number; low and high end bracket the measured number.
By their numbers in this assay, from the lowest: compound 2; then compound 3; then compound 1.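

In this assay the move to 3-fluoro-5-methylphenyl brings a 2.8-fold higher number from compound 2 to compound 3 (0.45 log units; beyond the scatter) and so gives up part of the earlier gain, even though the leaving and entering groups have the same count of heavy atoms. Set against the dichlorinated ring, the same group still gives a 3.5-fold lower number from compound 1 to compound 3 (0.54 log units; beyond the scatter) and so the three aryl groups on the sulfonamide nitrogen now form a graded series instead of a single jump. No measurement is available that explains this order.

The change from compound 2 to compound 3 swaps chlorine for fluorine and also alters where the halogen sits, so the two effects cannot be separated; 3-chloro-5-methylphenyl would address this. As far as these compounds go, how a ring bearing a methoxy group or a nitrile, or a saturated cyclohexyl group, would behave at this nitrogen also stays open.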